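Removing the sulfonyl ester on the phenolic oxygen

The source may hold more compounds than are shown below. What is called first, only, known or untested is meant among the compounds shown, and "the series" means these compounds.

Compound 1, `Cc1c(O)ccc2c1[C@H](Cn1cc(-c3ccccc3)nn1)[C@@]13CC(=O)[C@@](C)(CC[C@@H]21)C3`: > 20000 nM
Compound 2, `Cc1c(O)ccc2c1[C@H](Cn1cc(-c3ccc(F)cc3)nn1)[C@@]13CC(=O)[C@@](C)(CC[C@@H]21)C3`: > 20000 nM
Compound 3, `Cc1ccc(S(=O)(=O)Oc2ccc3c(c2C)[C@H](Cn2cc(-c4ccccn4)nn2)[C@@]24CC(=O)[C@@](C)(CC[C@@H]32)C4)cc1`: > 20000 nM

In a functional assay on SW480 cells (Homo sapiens) for cytotoxicity, read by MTT assay, with a stated time of 4 days (on this read-out higher numbers stand for weaker inhibition and lower numbers for stronger inhibition), compound 1 gives > 20000 nM, which is a limit of the assay and not a number. Compound 2 is likewise read only as a limit there, at > 20000 nM. Compound 3 too stands at a limit, > 20000 nM. Among the measured compounds shown here, compound 3 therefore stands where every value shown stands, at the limit of > 20000 nM in this assay, at which 3 of the 3 values shown sit; no measured compound gives a number at all.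

For the measured compounds named here, the one step measured between neighbours, a step that the two limits leave unreadable from compound 1 to compound 2, cannot be read, since both of its ends sit at the limit, and so no measured step bears directly on the change to compound 4, `Cc1c(O)ccc2c1[C@H](Cn1cc(-c3ccccn3)nn1)[C@@]13CC(=O)[C@@](C)(CC[C@@H]21)C3`. That change is hydrogen in place of (4-methylphenyl)sulfonyl on an oxygen on an aromatic ring. Compounds 1 and 2 already carry the hydroxy group that compound 4 would carry, and neither of them gives a number. With nothing but limits behind it, compound 4 is expected to remain at the limit as well, a step that the limit leaves unreadable from compound 3 to compound 4 that cannot be read as a gain or a loss beyond the scatter. The estimate for compound 4 is 25000 nM, within 8000 nM to 80000 nM, with the expectation that this assay most likely reports only a limit again.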

Compound 4, half-maximal inhibitory concentration: > 20000 nM
Compound 4 was reported as a limit; the forecaster's own chance of this, stated with the estimate: 85%; the middle value lies beyond the limit too.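

In this assay compound 4 gives > 20000 nM, which is a limit and not a number. Among the compounds shown here, no new step from compound 1, compound 2 or compound 3 to compound 4 can be read, since both ends of each sit at a limit. The values shown all stand together: the limit of > 20000 nM in this assay, at which 4 of the 4 values shown sit. The compounds shown leave open whether hydroxy or ((4-methylphenyl)sulfonyl)oxy, or pyridin-2-yl, phenyl or 4-fluorophenyl, makes any difference in this assay.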